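Acylurea thiazole hydrazones: methoxyphenyl in place of fluorophenyl

A few compounds are considered here, and "the series" means these few. Any claim that something is new, unique, unknown or untested is made for them only; others in the source may bear on it.

Measured so far:
compound 1 `Cc1nc(N(C)C(=O)NC(=O)c2c(F)cccc2F)sc1C(=O)N/N=C/c1ccccc1F`: > 100 ug/mL
compound 2 `CN(C(=O)NC(=O)c1ccc(Cl)c(Cl)c1)c1nc(C(F)(F)F)c(C(=O)N/N=C/c2ccc([N+](=O)[O-])cc2)s1`: 6.85 ug/mL
compound 3 `CN(C(=O)NC(=O)c1cccc(C(F)(F)F)c1)c1nc(C(F)(F)F)c(C(=O)N/N=C/c2ccccc2C(F)(F)F)s1`: 10.4 ug/mL

In a functional assay on HepG2 cells (Homo sapiens) for inhibition, read by MTT assay, with a stated time of 72 h (on this read-out higher numbers stand for weaker inhibition and lower numbers for stronger inhibition), compound 1 gives > 100 ug/mL; this is a limit of the assay, not a number. Compound 2 gives 6.85 ug/mL in this assay. Compound 3 gives 10.4 ug/mL in this assay. Compound 1 sits at the limit of > 100 ug/mL in this assay, at which 1 of the 3 values shown sits, so its position among the shown numbers is known only as a limit.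

Compound 4 `COc1ccc(/C=N/NC(=O)c2sc(N(C)C(=O)NC(=O)c3c(F)cccc3F)nc2C)cc1` differs from compound 1 by 4-methoxyphenyl in place of 2-fluorophenyl on a carbon with a double bond to nitrogen. No measured step of this kind is shown, so no direction beyond the scatter is expected. The step from compound 1 to compound 4 is expected to be an at least 1.2-fold lower number from compound 1 to compound 4 (0.09 log units; that floor lies within the scatter). For compound 4 the value in this assay is estimated at 80 ug/mL, with a range from 30 ug/mL to 200 ug/mL.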

Compound 4, half-maximal inhibitory concentration: 22.7 ug/mL
Compound 4: middle estimate off by 3.5-fold (0.55 log units), on the high side; the measured number lies below the stated range.
By their numbers in this assay, from the lowest: compounds 2 and 3 (each within the scatter of the next); then compound 4. At a limit, above all of these: compound 1.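

In this assay, 4-methoxyphenyl in place of 2-fluorophenyl on a carbon with a double bond to nitrogen gives an at least 4.4-fold lower number from compound 1 to compound 4 (0.64 log units; beyond the scatter). Within the data shown here, this is the first single-place change that can be read, and it shows that this position alone can move the shared core of compound 1 to a measurable number. The size of the step remains a floor: the limit of > 100 ug/mL in this assay, at which 1 of the 4 values shown sits.

The compounds shown do not separate the effect of the entering methoxy group from that of the leaving fluorine. They also leave open how an amine or a carboxylic acid on this phenyl ring would read.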